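This account rests on a few compounds, and the source may have more. Where it says the series, first, only, none or still open, it means among the compounds named here.

Measured in a functional assay on CCRF-CEM cells (Homo sapiens) for cytotoxicity, with a stated time of 72 h; on this read-out lower numbers stand for stronger inhibition and higher numbers for weaker inhibition:
compound 1, `C=CCOc1ccc(/C=C/C(=O)c2ccc(OCC=C(C)C)c(CC=C)c2)cc1OC`, gives only a limit: > 50000 nM
compound 2, `C#CCOc1ccc(C(C)=O)cc1CC=C`, gives 38200 nM
compound 3, `C=CCc1cc(C(C)=O)ccc1OCC=C(C)C`, gives 16300 nM

Compound 4, `C#CCOc1ccc(C(=O)/C=C/c2ccc(OCC=C)c(OC)c2)cc1CC=C`, has not yet been measured. It differs from compound 1 by ethynyl in place of 2-methylprop-1-en-1-yl on a saturated chain carbon bound to an oxygen on an aromatic ring. The same change, from compound 3 to compound 2, gave a 2.3-fold higher number from compound 3 to compound 2 (0.37 log units; beyond the scatter). How the core of compound 1 differs from the core of compound 3 is not broken down here. Compound 1 sits at the limit of > 50000 nM in this assay, at which 1 of the 3 values shown sits, so its own value is known only as a limit. The expected step from compound 1 to compound 4 is a step that the limit leaves unreadable from compound 1 to compound 4, resting on a 2.3-fold higher number from compound 3 to compound 2 (0.37 log units; beyond the scatter), which makes a further weakening more likely than a gain. Compound 4 is therefore expected to give about 70000 nM, estimated between 25000 nM and 200000 nM, most likely again only as a limit.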

Compound 4, half-maximal inhibitory concentration: > 50000 nM
Compound 4: a limit, no number (the forecaster's own chance of this, stated with the estimate: 75%); the middle value lies beyond the limit too.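

In this assay, for the compounds shown here, compound 1 and compound 4 both give only a limit, not a number, so no step between them can be read: the limit of > 50000 nM in this assay, at which 2 of the 4 values shown sit. As far as these compounds go, whether ethynyl in place of 2-methylprop-1-en-1-yl weakens or strengthens inhibition on the core of compound 1 stays open.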